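Two Benzoxaborole Pyrroles Beyond the Cytotoxicity Limit

The source may hold more compounds than are shown below. What is called first, only, known or untested is meant among the compounds shown, and "the series" means these compounds.

Of the compounds shown here, two have been measured for how much they harm a mouse cell line. The first, compound 1 `OB1OCc2ccc(-n3cc(Sc4ccccc4O)c4ccccc43)cc21`, was tested in an ADME assay on L929 cells (Mus musculus) for cytotoxicity, read by resazurin assay, with a stated time of 72 h; a higher number here means a weaker inhibitor, a lower number a stronger inhibitor. In this assay compound 1 gives > 10 ug/mL, which is a limit of the assay rather than a number. The second, compound 2 `O=C(c1ccc(F)cc1)c1ccn(-c2ccc3c(c2)B(O)OC3)c1`, shares with compound 1 a benzoxaborole ring attached to a nitrogen-containing five-membered ring. In this assay compound 2 gives > 10 ug/mL, again a limit of the assay and not a measured value. So compound 2 stands at the edge of what the assay can report, and the only other value shown sits there too: the limit of > 10 ug/mL in this assay, at which 2 of the 2 values shown sit.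

The next compound, compound 3 `Cc1cccc(C(=O)c2ccn(-c3ccc4c(c3)B(O)OC4)c2)c1`, differs from compound 2 in one place: 3-methylphenyl in place of 4-fluorophenyl on a carbonyl carbon. Among the compounds with values here, no measured pair in this set shows what such a swap does, so the expected step from compound 2 to compound 3 is a step that the limit leaves unreadable from compound 2 to compound 3, not beyond the usual scatter. On that basis, compound 3 is estimated to give 15 ug/mL, within a range from 8 ug/mL to 40 ug/mL, most likely reported again only as a limit.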

Compound 3, half-maximal inhibitory concentration: > 10 ug/mL
Compound 3: no number, only a limit (the forecaster's own chance of this, stated with the estimate: 80%); the middle value is on the limit's open side.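

Compound 2 and compound 3 each give only a limit of the assay rather than a number, so no step can be read between them. The whole set shown sits at one value: the limit of > 10 ug/mL in this assay, at which 3 of the 3 values shown sit.

On these data alone, what stays open is how far each compound lies past that limit, and whether 3-methylphenyl in place of 4-fluorophenyl makes any difference in this assay.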